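The source may report more compounds than this note shows. Statements on the series, on what has been measured and on what is new or still open speak of the compounds shown alone.

Measured so far in an assay on isolated protein for inhibition of phosphatidylinositol 4,5-bisphosphate 3-kinase catalytic subunit beta isoform (Homo sapiens), read by 33P incorporation, with a stated time of 60 min; a lower number here means a stronger inhibitor, a higher number a weaker inhibitor:
compound 1, `COc1ccc([N+](=O)[O-])cc1S(=O)(=O)N(C)/N=C/c1cnn2ccc(C#N)cc12`, gives 63 nM;
compound 2, `Cc1ccc(N)cc1S(=O)(=O)N(C)/N=C/c1cnn2ccc(C#N)cc12`, gives > 1000 nM;
compound 3, `Cc1ccc([N+](=O)[O-])cc1CN(C)/N=C/c1cnn2ccc(C#N)cc12`, gives 79 nM.

Compound 2 stands apart from the other two. Its result is not a number but a limit of the assay: it sits at the limit of > 1000 nM in this assay, at which 1 of the 3 values shown sits, so only an upper bound on its strength is known. Compounds 1 and 3, which do not carry the amino group, give values within the scatter of each other.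

The new compound, compound 4, `Cc1ccc(C)c(S(=O)(=O)N(C)/N=C/c2cnn3ccc(C#N)cc23)c1`, arises from compound 2 by one change: methyl in place of amino on an aromatic carbon. Going by the values given here, no measured pair in this set differs by exactly this change, so the size of the step has to be guessed from the neighbours. Because compound 2 sits at the limit of > 1000 nM in this assay, at which 1 of the 3 values shown sits, a value for compound 4 anywhere at or below that limit would be consistent with the data; the two compounds without the amino group suggest that losing it need not cost potency. The expectation is therefore a step of moderate size from compound 2 to compound 4 toward stronger inhibition in this assay, about an at least 2.5-fold lower number from compound 2 to compound 4 (0.39 log units; beyond the scatter), with wide uncertainty.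

For compound 4 the estimate in this assay is 400 nM, within a range from 100 nM to 2500 nM.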

Compound 4, half-maximal inhibitory concentration: > 1000 nM
Compound 4: only a limit was reported; the forecaster's own chance of this, stated with the estimate: 30%; at least 2.5-fold (0.39 log units) between middle value and limit.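

In this assay compound 4 gives > 1000 nM, which is a limit of the assay and not a number. Going by these compounds alone, compound 2 rests at the same limit, so no step between compound 2 and compound 4 can be read: the limit of > 1000 nM in this assay, at which 2 of the 4 values shown sit. The compounds shown leave open whether methyl in place of amino changes inhibition at all.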